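The source may report more compounds than this note shows. Statements on the series, on what has been measured and on what is new or still open speak of the compounds shown alone.

In a functional assay on MIA PaCa-2 cells (Homo sapiens) for antiproliferative activity (on this read-out lower numbers stand for an effect already at smaller amounts and higher numbers for an effect only at larger amounts of compound), compound 1 `Cc1cc2c(C(N)=O)cccc2n1-c1nc2c(c(NCc3ccccc3)n1)CCCC2` gives 128 nM, while compound 2 `CCCNC(=O)c1cccc2c1cc(C)n2-c1nc2c(c(NCc3ccccc3)n1)CCCC2` gives 608 nM, the higher of the two numbers. For the measured compounds named here, the only measured step, a 4.8-fold higher number from compound 1 to compound 2 (0.68 log units; beyond the scatter), puts propyl in place of the amide hydrogen. Compound 3 `C#CC(=O)Nc1cccc2c1cc(C)n2-c1nc2c(c(NCc3ccccc3)n1)CCCC2` replaces this whole side group: (ethynylcarbonyl)amino in place of propylcarbamoyl on an aromatic carbon. Going by the values given here, no measured compound carries the new group, so the earlier step is only a loose guide. With the propyl gone, a modest move toward a lower number is expected in this assay. The expected step is a 2.4-fold lower number from compound 2 to compound 3 (0.39 log units; beyond the scatter). For compound 3, the estimated value is 250 nM, with a range from 50 nM to 1200 nM.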

Compound 3, half-maximal effective concentration: 131 nM
Compound 3: the middle estimate sits 1.9-fold (0.28 log units) above what was measured, and the stated range covers the measured number.
By their numbers in this assay, from the lowest: compounds 1 and 3 (each within the scatter of the next); then compound 2.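

In this assay, this aromatic carbon accepts a differently built side group: (ethynylcarbonyl)amino gives a 4.6-fold lower number from compound 2 to compound 3 (0.67 log units; beyond the scatter), and compared with the plain carbamoyl group it gives a 1.0-fold higher number from compound 1 to compound 3 (0.01 log units; within the scatter). Of the three groups shown at this place, only propylcarbamoyl stands apart, so a high number does not come with every larger group here. No supporting data explain this result. Still open, from the compounds shown here alone, is how an acetylamino group, which lacks the triple bond, or a carboxylic acid would read at this carbon. Going by these compounds, a methyl in place of the propyl on the amide nitrogen is also open.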